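The source may hold more compounds than are shown below. What is called first, only, known or untested is meant among the compounds shown, and "the series" means these compounds.

Working notes on the series, read in a functional assay on BT-549 cells (Homo sapiens) for inhibition, read by sulforhodamine B assay, with a stated time of 6 days; on this read-out higher numbers stand for weaker inhibition and lower numbers for stronger inhibition. Compound 1 `CNCCNCc1cccc(-c2nc(NC3CCOCC3)c(C)c(-c3cncnc3)n2)c1` returns only a limit, > 50000 nM. Compound 2 `CNCCNCc1cccc(-c2nc(NC3CCOCC3)c(C)c(-c3cccnc3)n2)c1` also returns only a limit, > 50000 nM. Compound 2 therefore has no numerical position in the series, and the evidence so far amounts to the limit of > 50000 nM in this assay, at which 2 of the 2 values shown sit.

Compound 3 `CNCCNCc1cccc(-c2nc(NC3CCOCC3)c(C)c(-c3cccc4cnccc34)n2)c1` keeps the shared core and differs from compound 2 at one place: isoquinolin-5-yl in place of pyridin-3-yl on an aromatic carbon. The change sits on an aromatic carbon next to the ring nitrogen and ortho to a methyl group.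

Among the measured compounds shown here, the only measured step, a step that the two limits leave unreadable from compound 1 to compound 2, has no readable size and gives no scale for this change. For the measured compounds named here, no measured step involves a group with two fused rings, so any forecast is weakly supported. The direction can only be towards stronger inhibition or no readable change, since the starting point is a limit. A modest move towards stronger inhibition is expected, although another limit remains slightly more likely than a number.

The expected step is an at least 1.6-fold lower number from compound 2 to compound 3 (0.22 log units; that floor lies within the scatter). For compound 3 the estimated value is 30000 nM, with an expected range from 8000 nM to 60000 nM.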

Compound 3, half-maximal inhibitory concentration: 32000 nM
For compound 3 the middle estimate is 1.1-fold (0.03 log units) below the measured one; the measured number falls inside the stated range.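

Among the compounds shown here, at this position, on an aromatic carbon next to the ring nitrogen and ortho to a methyl group, compound 3 gives the first number of the series in this assay, 32000 nM. Isoquinolin-5-yl, with its second six-membered aromatic ring, thus yields a readable value where pyridin-3-yl and pyrimidin-5-yl gave only limits, with an at least 1.5-fold lower number from compound 2 to compound 3 (0.19 log units; that floor lies within the scatter) and an at least 1.5-fold lower number from compound 1 to compound 3 (0.19 log units; that floor lies within the scatter). Both steps are known only as floors that lie within the scatter, so neither sets a true size for the change, and the step between the two limits cannot be read at all.

The compounds shown do not tell whether the readable value goes with the added carbon-only ring of isoquinolin-5-yl or with its ring nitrogen, and a naphthalen-1-yl group on the same aromatic carbon would separate the two. The series also has only one number to build on, and the remaining evidence stays at the assay limit: the limit of > 50000 nM in this assay, at which 2 of the 3 values shown sit.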